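Side-chain variants on a shared core: growth inhibition notes

This account rests on a few compounds, and the source may have more. Where it says the series, first, only, none or still open, it means among the compounds named here.

compound 1, `NC(=O)/C=C/c1ccncc1-c1ccc2ccccc2c1`: > 10000 nM, a limit only
compound 2, `COC1CN(C(=O)/C=C/c2ccncc2-c2ccc3ccccc3c2)C1`: > 10000 nM, a limit only
compound 3, `O=C(O)CCc1ccncc1-c1ccc2ccccc2c1`: > 10000 nM, a limit only

In a functional assay on MDA-MB-231 cells (Homo sapiens) for inhibition, read by sulforhodamine B assay, with a stated time of 72 h (on this read-out higher numbers stand for weaker inhibition of growth and lower numbers for stronger inhibition of growth), compound 3 gives only a limit, > 10000 nM. Compound 1 likewise gives only a limit. Compound 2 likewise gives only a limit. Compound 3 therefore cannot be placed against the other two, and the limit of > 10000 nM in this assay, at which 3 of the 3 values shown sit, is all the three values show. The step to compound 4, `COC(=O)/C=C/c1ccncc1-c1ccc2ccccc2c1`, is 2-(methoxycarbonyl)ethenyl in place of 2-carboxyethyl on an aromatic carbon. The two steps already measured, a step that the two limits leave unreadable from compound 1 to compound 2 and a step that the two limits leave unreadable from compound 1 to compound 3, are unreadable from the limits and give no size. No direction follows from them; the expectation rests on compound 3 alone. Compound 4 is expected to stay at the limit, estimated at 15000 nM (4000 nM to 60000 nM). The step this estimate means, a step that the limit leaves unreadable from compound 3 to compound 4, is expected to be none beyond the scatter.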

Compound 4, concentration for 50% growth inhibition: 4710 nM
Beside the measured number, compound 4's estimate is 3.2-fold (0.50 log units) above it; measured number inside the range.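

In this assay, 2-(methoxycarbonyl)ethenyl on the aromatic carbon opposite the ring nitrogen is the only side chain shown that comes off the limit: the limit of > 10000 nM in this assay, at which 3 of the 4 values shown sit. Against the full side-chain change (an at least 2.1-fold lower number from compound 3 to compound 4 (0.32 log units; beyond the scatter)), methoxy on the carbonyl carbon also reads in place of amino (an at least 2.1-fold lower number from compound 1 to compound 4 (0.32 log units; beyond the scatter)) and in place of 3-methoxyazetidin-1-yl (an at least 2.1-fold lower number from compound 2 to compound 4 (0.32 log units; beyond the scatter)). The steps from compound 1 to compound 2 and to compound 3 cannot be read.

From the compounds shown here alone, compound 4 differs from compound 3 in both the chain double bond and the ester, so which of the two carries the step stays open. A carboxylic acid on the ethenyl chain, a saturated methyl ester or an ethyl ester would separate these.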